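Cyclohexylsulfonyl in place of ethylsulfonyl: compound 4

The source may hold more compounds than are shown below. What is called first, only, known or untested is meant among the compounds shown, and "the series" means these compounds.

The series shares one core and varies the group on an amine nitrogen in a ring, tested in a functional assay on CHO-K1 cells for agonist activity at Glucose-dependent insulinotropic receptor (Homo sapiens), read by a luciferase reporter, with a stated time of 5 h; on this read-out lower numbers stand for an effect already at smaller amounts and higher numbers for an effect only at larger amounts of compound. Compound 1 `CC(C)NC(=O)CN1CCN(c2ccc(OCC3CCN(C(=O)OC(C)C)CC3)cn2)CC1` gives only the limit > 10000 nM in this assay. Compound 2 `CC(=O)N1CCN(c2ccc(OCC3CCN(C(=O)OC(C)C)CC3)cn2)CC1` likewise gives only the limit > 10000 nM in this assay. Among the compounds with values here, compound 3 `CCS(=O)(=O)N1CCN(c2ccc(OCC3CCN(C(=O)OC(C)C)CC3)cn2)CC1`, carrying ethylsulfonyl, gives 1300 nM in this assay and is the only member with a number. Compound 1 and compound 2 each sit at the limit of > 10000 nM in this assay, at which 2 of the 3 values shown sit. The steps of an at least 7.6-fold lower number from compound 1 to compound 3 (0.88 log units; beyond the scatter) and an at least 7.6-fold lower number from compound 2 to compound 3 (0.88 log units; beyond the scatter) both install ethylsulfonyl on the ring nitrogen in place of another group. Compound 4 `CC(C)OC(=O)N1CCC(COc2ccc(N3CCN(S(=O)(=O)C4CCCCC4)CC3)nc2)CC1` keeps the sulfonyl and differs from compound 3 in cyclohexyl in place of ethyl on a sulfonyl sulfur. Within the data shown here, no measured step varies the alkyl on the sulfonyl sulfur, so the recorded steps speak to the presence of the sulfonyl, not to its size. The step of a 1.4-fold lower number from compound 3 to compound 4 (0.16 log units; within the scatter) is therefore expected to stay within the scatter. The estimate for compound 4 in this assay is 900 nM, between 200 nM and 4000 nM.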

Compound 4, half-maximal effective concentration: 200 nM
For compound 4 the middle estimate is 4.5-fold (0.65 log units) above the measured one; the measured number falls inside the stated range.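

Within the data shown here, the size of the alkyl on the sulfonyl sulfur matters: cyclohexyl in place of ethyl gives a 6.5-fold lower number from compound 3 to compound 4 (0.81 log units; beyond the scatter), the first measured step at this place. Against the groups that carry no sulfonyl, cyclohexylsulfonyl gives an at least 50-fold lower number from compound 2 to compound 4 (1.69 log units; beyond the scatter) for acetyl and an at least 50-fold lower number from compound 1 to compound 4 (1.69 log units; beyond the scatter) for (isopropylcarbamoyl)methyl. Both of these steps start from a limit and not from a number, so their true size remains unknown: the limit of > 10000 nM in this assay, at which 2 of the 4 values shown sit.

Whether the gain follows the ring or only the carbon count stays open, since ethyl and cyclohexyl are the only groups shown on the sulfur, and a straight hexyl chain, a cyclopentyl or a phenyl would separate these readings. Also open, on these data alone, is whether the step holds when a tert-butyl carbamate stands in place of the isopropyl carbamate.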